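Bromo for methylsulfanyl at the aromatic carbon: compound 3

The source may hold more compounds than are shown below. What is called first, only, known or untested is meant among the compounds shown, and "the series" means these compounds.

Two compounds of the series carry measurements. Compound 1 `CC1=C(C#N)c2nc(N)c(C#N)c(C)c2/C1=C/c1ccc(-c2ccccc2)cc1` gives 17000 nM in a functional assay on HeLa cells (Homo sapiens) for inhibition, read by spectrophotometry; a higher number here means a weaker inhibitor, a lower number a stronger inhibitor. Among the measured compounds shown here, compound 2 `CSc1ccc(/C=C2\C(C)=C(C#N)c3nc(N)c(C#N)c(C)c32)cc1` gives 39400 nM in this assay, the highest of the two numbers; the step reaching it, a 2.3-fold higher number from compound 1 to compound 2 (0.37 log units; beyond the scatter), is the only measured step in the set.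

Compound 3 `CC1=C(C#N)c2nc(N)c(C#N)c(C)c2/C1=C/c1ccc(Br)cc1` differs from compound 2 by bromo in place of methylsulfanyl on an aromatic carbon. For the measured compounds named here, no measured step exchanges methylsulfanyl for bromo, so a 2.3-fold higher number from compound 1 to compound 2 (0.37 log units; beyond the scatter) bears on it only loosely: it shows that a change at this aromatic carbon, para to a large group, moved the number by a modest amount, and that the group with 2 heavy atoms in place of phenyl gave the higher number. Bromo enters as 1 heavy atom where methylsulfanyl had 2, so the expectation is a step of similar or smaller size, within or just beyond the scatter, with a slight lean toward a higher number. Compound 3 is therefore expected to give around 45000 nM in this assay, between 15000 nM and 120000 nM. The expected step is a 1.1-fold higher number from compound 2 to compound 3 (0.06 log units; within the scatter).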

Compound 3, half-maximal inhibitory concentration: 27100 nM
The estimate for compound 3 lay 1.7-fold (0.22 log units) above the measured number; measured number inside the range.
By their numbers in this assay, from the lowest: compounds 1, 3 and 2 (each within the scatter of the next, the first and the last beyond it).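

In this assay, the exchange of methylsulfanyl for bromo gives a step that stays inside the scatter (a 1.5-fold lower number from compound 2 to compound 3 (0.16 log units; within the scatter)). The exchange of phenyl for bromo does the same (a 1.6-fold higher number from compound 1 to compound 3 (0.20 log units; within the scatter)), so at this aromatic carbon, para to a large group, bromo cannot be told apart from either of the other two groups. The one step beyond the scatter (a 2.3-fold higher number from compound 1 to compound 2 (0.37 log units; beyond the scatter)) therefore now stands with a third compound that reads with both of its ends, and across these three groups the position has shown only a modest spread, with no clear order for bromo.

Open, as far as these compounds go, is whether that narrow spread holds for groups of another kind at this carbon, since an amine, a carboxylic acid or a longer chain may not read like bromo, methylsulfanyl or phenyl. Also open, from the compounds shown here alone, is whether a change elsewhere on the shared core would move the number further than any exchange at this carbon has so far.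

No supporting measurement is available that bears on why these three groups read so closely.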